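Replacing the hydroxy-methylphenyl arm with a bromophenyl arm

The compounds below may be only part of what the source reports. "The series", "measured", "known", "first", "only" and "open" are said of these compounds alone.

Measured so far:
compound 1 `O=C1Nc2ccc(Br)cc2/C1=N/NC(=S)N/N=C/c1ccc(-c2ccccc2)cc1` gives 3250 nM
compound 2 `O=C1Nc2ccc(Br)cc2/C1=N/NC(=S)N/N=C/c1c(F)cccc1Cl` gives 1610 nM
compound 3 `Cc1ccc(O)c(/C=N/NC(=S)N/N=C2\C(=O)Nc3ccc(Br)cc32)c1` gives > 50000 nM

All three share one core and differ only in the aryl group attached to a carbon with a double bond to nitrogen. In a functional assay on HeLa cells (Homo sapiens) for inhibition, read by MTT assay (a lower number here means a stronger inhibitor, a higher number a weaker inhibitor), compound 1 gives 3250 nM and compound 2 gives 1610 nM; these two values lie within the scatter of each other. For compound 3 the result is only a limit, > 50000 nM, which places compound 3 at the weak end of the three. For the measured compounds named here, the one directly comparable step is an at least 31-fold higher number from compound 2 to compound 3 (1.49 log units; beyond the scatter), a large loss when the 2-hydroxy-5-methylphenyl group enters; the value for compound 3 rests on (the limit of > 50000 nM in this assay, at which 1 of the 3 values shown sits).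

Compound 4 `O=C1Nc2ccc(Br)cc2/C1=N/NC(=S)N/N=C/c1ccc(Br)cc1` has not yet been measured. It differs from compound 3 by 4-bromophenyl in place of 2-hydroxy-5-methylphenyl on a carbon with a double bond to nitrogen. This change removes the group whose arrival caused the large loss from compound 2 to compound 3 and puts in its place a plain halogenated phenyl, closer in kind to the groups of compound 1 and compound 2. The expected step is therefore a large move to a lower number, an at least 20-fold lower number from compound 3 to compound 4 (1.30 log units; beyond the scatter), back toward the range of those two compounds. The estimate for compound 4 in this assay is 2500 nM, with a range from 800 nM to 15000 nM.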

Compound 4, half-maximal inhibitory concentration: 4680 nM
For compound 4 the middle estimate is 1.9-fold (0.27 log units) below the measured one; the measured number falls inside the stated range.
By their numbers in this assay, from the lowest: compound 2; then compounds 1 and 4 (each within the scatter of the next). At a limit, above all of these: compound 3.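

Putting 4-bromophenyl on the carbon with a double bond to nitrogen in place of 2-hydroxy-5-methylphenyl gives an at least 10-fold lower number from compound 3 to compound 4 (1.02 log units; beyond the scatter) in this assay, so the large loss seen with compound 3 is not a feature of the shared core and goes away when this one group is exchanged. The size of that step is only a lower bound, since the result for compound 3 is a limit and not a number: the limit of > 50000 nM in this assay, at which 1 of the 4 values shown sits. Compound 4 also shows how much the other aryl groups at this place differ among themselves: there is a 2.9-fold higher number from compound 2 to compound 4 (0.46 log units; beyond the scatter), a modest change, whereas a 1.4-fold higher number from compound 1 to compound 4 (0.16 log units; within the scatter) stays within the scatter, so bromo and phenyl on that aromatic carbon cannot be told apart here.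

The compounds shown do not separate the hydroxy from the methyl of the 2-hydroxy-5-methylphenyl group, so a phenyl carrying only one of the two would be needed to say which goes with the loss. Also open, from the compounds shown here alone, is how an amine or a carboxylic acid in place of the bromo of compound 4 would read in this assay.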